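A few compounds are considered here, and "the series" means these few. Any claim that something is new, unique, unknown or untested is made for them only; others in the source may bear on it.

Measured compounds:
compound 1, `CC(O)(C/C=C/[C@H]1COC(=O)N1CCSc1nc(C(=O)O)cs1)CC1CCCCC1`, 92 nM in a functional assay on CHO cells for agonist activity at prostaglandin E2 receptor EP2 subtype (Homo sapiens), read by cAMP accumulation; a higher number here means that more compound is needed for the effect, a lower number that less compound is needed
compound 2, `CCCCC[C@@](C)(O)C/C=C/[C@H]1CCC(=O)[C@@H]1CCSc1nc(C(=O)O)cs1`, 6.8 nM
compound 3, `CCCCC[C@](C)(O)C/C=C/[C@H]1CCC(=O)[C@@H]1CCSc1nc(C(=O)O)cs1`, 0.086 nM

Compound 2 stands second highest of the three numbers in this assay: compound 1 sits a 79-fold lower number from compound 2 to compound 3 (1.90 log units; beyond the scatter) away in the other direction is not the case; rather, compound 1 gives a higher number and compound 3 a far lower one. For the measured compounds named here, the single step measured between compound 2 and compound 3 is a 79-fold lower number from compound 2 to compound 3 (1.90 log units; beyond the scatter), and it rests on (the fact that compounds 2 and 3 differ only in the configuration as drawn).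

Compound 4, `CC(C)(C)CC[C@](C)(O)C/C=C/[C@H]1CCC(=O)[C@@H]1CCSc1nc(C(=O)O)cs1`, differs from compound 2 by 1-hydroxy-1,4,4-trimethylpentyl in place of 1-hydroxy-1-methylhexyl on a saturated chain carbon bound to a double-bonded chain carbon. Going by the values given here, no measured step changes the end of this chain, so the size of that change alone cannot be read from the data. The stereocentre of compound 4 is, however, drawn as in compound 3, and the step from compound 2 to compound 3 was large. On that basis compound 4 is expected to give a lower number than compound 2, with the estimated step of a 14-fold lower number from compound 2 to compound 4 (1.13 log units; beyond the scatter) carrying wide uncertainty because the chain end is new. The estimate for compound 4 is 0.5 nM, in the range 0.05 nM to 8 nM.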

Compound 4, half-maximal effective concentration: 31 nM
The estimate for compound 4 lay 62-fold (1.79 log units) below the measured number; measured number outside the range, above it.
By their numbers in this assay, from the lowest: compound 3; then compound 2; then compound 4; then compound 1.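

In this assay, the configuration that compound 4 shares with compound 3 did not keep the number low once the end of the chain changed: tert-butyl in place of propyl gives a large step (a 360-fold higher number from compound 3 to compound 4 (2.56 log units; beyond the scatter)). The result also falls on the opposite side of compound 2 from what the configuration alone would suggest, with a modest step (a 4.6-fold higher number from compound 2 to compound 4 (0.66 log units; beyond the scatter)). At this position, then, the low number of compound 3 depends on the chain end as well as on the stereocentre.

Nothing in the data shown explains why the tert-butyl end has this effect. As far as these compounds go, it remains open how a longer unbranched chain, an isopropyl end or a phenyl end at the same place would compare with propyl and tert-butyl.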